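The source may report more compounds than this note shows. Statements on the series, on what has been measured and on what is new or still open speak of the compounds shown alone.

Measured in an ADME assay on HEK-293T cells (Homo sapiens) for cytotoxicity, read by MTT assay, with a stated time of 48 h; on this read-out higher numbers stand for lower toxicity in this test and lower numbers for higher toxicity in this test:
- Compound 1 `COc1ccc2c(c1)c(C1CC(c3ccc(Cl)cc3)=NN1C(=O)c1ccc(OC)nc1)cn2C`: > 300000 nM, a limit.
- Compound 2 `COc1ccc2c(c1)c(C1CC(c3ccc(Br)cc3)=NN1C(=O)c1ccc(OC)nc1)cn2C`: > 300000 nM, a limit.
- Compound 3 `COc1cccc(C2=NN(C(=O)c3cccnc3)C(c3cn(C)c4ccc(OC)cc34)C2)c1`: 125000 nM.

Within the data shown here, compound 3 is the only compound with an actual number, while compound 1 and compound 2 share (the limit of > 300000 nM in this assay, at which 2 of the 3 values shown sit). Compound 4 `COc1cccc(C2=NN(C(=O)c3ccc(OC)nc3)C(c3cn(C)c4ccc(OC)cc34)C2)c1` is compound 3 with methoxy in place of hydrogen on an aromatic carbon, next to the ring nitrogen and para to a large group, so that pyridin-3-yl becomes 6-methoxypyridin-3-yl: methoxy in place of hydrogen on an aromatic carbon.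

Among the measured compounds shown here, the only measured step is a step that the two limits leave unreadable from compound 1 to compound 2. It is a bromo for chloro exchange, has no readable size and does not involve the methoxy change. The sole lead on direction is that compound 1 and compound 2 already carry the 6-methoxypyridin-3-yl group and stand at the limit of > 300000 nM in this assay, at which 2 of the 3 values shown sit. They also differ from compound 3 elsewhere, so no size can be read from them. A move in this assay towards higher numbers is therefore expected, but a modest one, possibly within the scatter, and it could reach the limit of the assay. The expected change is a 1.6-fold higher number from compound 3 to compound 4 (0.20 log units; within the scatter). For compound 4 the estimate is 200000 nM, with an expected range of 90000 nM to 450000 nM.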

Compound 4, half-maximal cytotoxic concentration: > 300000 nM
Compound 4 gave a limit, no number (the forecaster's own chance of this, stated with the estimate: 45%); middle value at least 1.5-fold (0.17 log units) away from the limit.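

In this assay, methoxy in place of hydrogen on an aromatic carbon of the pyridin-3-yl group, next to the ring nitrogen and para to a large group, gives an at least 2.4-fold higher number from compound 3 to compound 4 (0.38 log units; beyond the scatter). Among these compounds, this is the first readable step and the first to bear on this position, although the value of compound 4 is a limit, so the step gives no upper size for the change. Compound 4 now shares one limit with compound 1 and compound 2, all three carry the 6-methoxypyridin-3-yl group, and compound 3, with pyridin-3-yl, is the only compound with an actual number: the limit of > 300000 nM in this assay, at which 3 of the 4 values shown sit.

The steps from compound 1 and from compound 2 to compound 4 cannot be read, which leaves the 3-methoxyphenyl, 4-chlorophenyl and 4-bromophenyl groups unranked on this read-out. Also open, from the compounds shown here alone, is how an amine or an ethoxy chain in place of the methoxy of compound 4 would read in this assay.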